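Replacing the acyl side group of compound 3

This account rests on a few compounds, and the source may have more. Where it says the series, first, only, none or still open, it means among the compounds named here.

In an ADME assay on microsomes from liver (Homo sapiens) for metabolic stability, with a stated time of 10 min (a higher number here means that more of the compound is left, a lower number that less of the compound is left), three compounds sharing one core have been read: compound 1 `CC(=O)N1CC[C@H](C(=O)N2CC[C@](c3ccc(C(OCc4c(F)cccc4F)(C(F)(F)F)C(F)(F)F)cc3)(S(=O)(=O)c3ccc(F)cc3)C2)C1` gives 19% while compound 2 `CC(=O)N1CC[C@@H](C(=O)N2CC[C@](c3ccc(C(OCc4c(F)cccc4F)(C(F)(F)F)C(F)(F)F)cc3)(S(=O)(=O)c3ccc(F)cc3)C2)C1` gives 9% and compound 3 `CC(=O)N1CCC(C)(C(=O)N2CC[C@](c3ccc(C(OCc4c(F)cccc4F)(C(F)(F)F)C(F)(F)F)cc3)(S(=O)(=O)c3ccc(F)cc3)C2)CC1` gives 1% in the same test. Between the first two the record shows a number 10 percentage points lower from compound 1 to compound 2 (within the scatter) and that pair reflects the fact that compounds 1 and 2 differ only in the configuration as drawn alone. Compound 3 stands low: the numbers show a number 18 percentage points lower from compound 1 to compound 3 (beyond the scatter) but also a number 8 percentage points lower from compound 2 to compound 3 (within the scatter) so only the gap to compound 1 counts as real.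

Compound 4 `O=C(C1CCOCC1)N1CC[C@](c2ccc(C(OCc3c(F)cccc3F)(C(F)(F)F)C(F)(F)F)cc2)(S(=O)(=O)c2ccc(F)cc2)C1` is the next case, and its change is oxan-4-yl in place of 1-acetyl-4-methylpiperidin-4-yl on a carbonyl carbon on the same core. For the measured compounds named here, the step into compound 3 at this same carbonyl carbon is the only guide to size, and it was modest from one partner and within the scatter from the other. Going by the values given here, no measured step brings in oxan-4-yl, so these steps offer a scale and no direction of their own. Compound 3 at 1% has little room left to fall, so any move for compound 4 is expected to be upward and small, with nothing far beyond the scatter. The estimate amounts to a number 9 percentage points higher from compound 3 to compound 4 (within the scatter) as the expected step. For compound 4 the estimated value is 10% with an expected range from 2% to 30% as the likely span.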

Compound 4, percent of the compound remaining: 11%
Compound 4: middle estimate off by 1 percentage points, on the low side; the measured number falls inside the stated range.
By their numbers in this assay, from the lowest: compounds 3, 2, 4 and 1 (each within the scatter of the next, the first and the last beyond it).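

In this assay, for the compounds shown here, oxan-4-yl is the only group at this carbonyl carbon that carries neither a ring nitrogen nor an acetyl group, and the exchange gives a number 10 percentage points higher from compound 3 to compound 4 (within the scatter) and likewise a number 2 percentage points higher from compound 2 to compound 4 (within the scatter) and a number 8 percentage points lower from compound 1 to compound 4 (within the scatter) on the same core. Compound 4 therefore cannot be told apart from any of the three earlier compounds, even though the two ends of the set are separated by a number 18 percentage points lower from compound 1 to compound 3 (beyond the scatter) and so do count as different. At this position, then, a ring without the acetyl group reads no differently from the acetylated rings, and the one real gap in the set is not resolved by the new group, which falls within the scatter of both ends.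

Going by these compounds, whether a plain cyclohexyl ring, or a ring bearing an amine or a carboxylic acid, would read clearly apart from these four at this carbonyl carbon stays open, as does the part played by the ring oxygen of oxan-4-yl. Nothing recorded here bears on why compound 4 reads as it does.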